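Notes on a biaryl amide series at GPR88

The source may report more compounds than this note shows. Statements on the series, on what has been measured and on what is new or still open speak of the compounds shown alone.

Measured so far:
- compound 1, `CC(C)C[C@H](N)CN(C(=O)[C@@H]1C[C@H]1c1ccccc1)c1ccc(-c2ccccc2)cc1`: 880 nM
- compound 2, `CC[C@H](C)[C@H](N)CN(C(=O)[C@@H]1C[C@H]1c1cccc(C)c1)c1ccc(-c2ccccc2)cc1`: 1200 nM

Both numbers come from a functional assay for agonist activity at G protein-coupled receptor 88 (Homo sapiens), read by HTRF and cAMP accumulation; on this read-out higher numbers stand for an effect only at larger amounts of compound and lower numbers for an effect already at smaller amounts. Compound 2 stands at the higher of the two numbers, but its nearest neighbour, compound 1, sits within the usual scatter of repeated measurements, so the two cannot be ranked against each other on this read-out. Within the data shown here, compound 1 and compound 2 differ in more than one place, so no single step between them can be drawn.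

The next compound, compound 3, `CC[C@H](C)[C@H](N)CN(C(=O)[C@@H]1C[C@H]1c1ccsc1)c1ccc(-c2ccccc2)cc1`, differs from compound 2 in one place only: thiophen-3-yl in place of 3-methylphenyl on a saturated ring carbon. The group that leaves is a six-membered aromatic ring of carbon only; the group that enters is a five-membered aromatic ring with one hetero atom and one hydrogen-bond acceptor, sitting on the same saturated ring carbon of the three-membered non-aromatic ring of carbon only.

Among the measured compounds shown here, no measured pair in this set shows what such an exchange does here. The expectation is therefore a step of a 1.2-fold higher number from compound 2 to compound 3 (0.07 log units; within the scatter), that is, no change beyond the scatter in either direction. On that basis compound 3 is estimated at 1400 nM, with a range from 500 nM to 4000 nM in this assay.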

Compound 3, half-maximal effective concentration: 450 nM
Beside the measured number, compound 3's estimate is 3.1-fold (0.49 log units) above it, and the stated range ends above it.
By their numbers in this assay, from the lowest: compounds 3, 1 and 2 (each within the scatter of the next, the first and the last beyond it).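

In this assay, thiophen-3-yl in place of 3-methylphenyl on a saturated ring carbon of the three-membered non-aromatic ring of carbon only gives a 2.7-fold lower number from compound 2 to compound 3 (0.43 log units; beyond the scatter). Among these compounds, this is the first single-place step and it lies beyond the scatter, so this position responds to the group it carries, and a five-membered aromatic ring with 1 hetero atom and fewer heavy atoms is accepted there, at least in this one pair. No measurement here says whether the ring size, the sulfur or the removal of the methyl accounts for the step.

Open, as far as these compounds go, is whether other five-membered or nitrogen-containing aromatic rings, such as furan-3-yl, thiophen-2-yl or pyridin-3-yl, would follow compound 3 on this carbon, and where an unsubstituted phenyl would fall with the side chain of compound 2. Also open, from the compounds shown here alone, is whether the same exchange would give a comparable step on the side chain of compound 1, since a single pair cannot show how far the result carries across the series.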